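Ethyl to isopropyl on the pyrazole of compound 3

A few compounds are considered here, and "the series" means these few. Any claim that something is new, unique, unknown or untested is made for them only; others in the source may bear on it.

The three measured compounds share one core and differ only in the pyrazole that sits on it. Compound 1 `CCNC(=O)c1noc(-c2cc(C(C)C)c(O)cc2O)c1-c1ccn(C)n1` carries a 1-methyl-1H-pyrazol-3-yl group; in a functional assay on A2780 cells (Homo sapiens) for inhibition (on this read-out lower numbers stand for stronger inhibition and higher numbers for weaker inhibition), compound 1 gives 12 nM. Compound 2 `CCNC(=O)c1noc(-c2cc(C(C)C)c(O)cc2O)c1-c1ccn(CC)n1` differs from compound 1 by methyl in place of hydrogen on a saturated chain carbon bound to an aromatic nitrogen. In this assay compound 2 gives 13 nM, so that a 1.1-fold higher number from compound 1 to compound 2 (0.03 log units; within the scatter). Compound 3 `CCNC(=O)c1noc(-c2cc(C(C)C)c(O)cc2O)c1-c1cnn(CC)c1` has a different core from compound 1, the difference being (1-ethyl-1H-pyrazol-4-yl in place of 1-methyl-1H-pyrazol-3-yl on an aromatic carbon); in this assay compound 3 gives 30 nM, and the steps are a 2.5-fold higher number from compound 1 to compound 3 (0.40 log units; beyond the scatter) and a 2.3-fold higher number from compound 2 to compound 3 (0.36 log units; beyond the scatter).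

Compound 4 `CCNC(=O)c1noc(-c2cc(C(C)C)c(O)cc2O)c1-c1cnn(C(C)C)c1` has not yet been measured. It differs from compound 3 by methyl in place of hydrogen on a saturated chain carbon bound to an aromatic nitrogen and a saturated chain carbon. Going by the values given here, this is the same kind of change as the one from compound 1 to compound 2, but not the same: there the place was on a saturated chain carbon bound to an aromatic nitrogen, whereas here it is on a saturated chain carbon bound to an aromatic nitrogen and a saturated chain carbon.

The earlier step, a 1.1-fold higher number from compound 1 to compound 2 (0.03 log units; within the scatter), was flat, and that single observation is all that the set offers for the change. Compound 4 is therefore expected to land close to compound 3, with a 1.1-fold higher number from compound 3 to compound 4 (0.04 log units; within the scatter). In this assay compound 4 is estimated at 33 nM, with a likely range from 15 nM to 70 nM, the width reflecting that the change is only a kind of repeat on a different core.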

Compound 4, half-maximal inhibitory concentration: 21 nM
Compound 4: middle estimate off by 1.6-fold (0.20 log units), on the high side; measured number inside the range.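

In this assay the change from ethyl to isopropyl on the 1-ethyl-1H-pyrazol-4-yl group gives a 1.4-fold lower number from compound 3 to compound 4 (0.15 log units; within the scatter), and set beside the earlier methyl addition, the step does not differ between the two cores: the same change on two cores in this assay, a 1.1-fold higher number (0.03 log units; within the scatter) from compound 1 to compound 2 and a 1.4-fold lower number (0.15 log units; within the scatter) from compound 3 to compound 4, 1.5-fold (0.19 log units) apart, within the scatter of two such steps Within this series, then, adding a methyl to the saturated chain carbon bound to the aromatic nitrogen left the number inside the scatter on both cores, so the flat outcome carried over from the core of compound 1 to the core of compound 3. Going by these compounds alone, this does not show that the change is neutral in general, since it rests on only two small steps, the carbon carrying the methyl is not substituted alike in the two cases, and two flat steps say nothing about a core on which the change might matter.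

Compound 4 also does not separate from the 1H-pyrazol-3-yl compounds, with a 1.6-fold higher number from compound 2 to compound 4 (0.21 log units; within the scatter) and a 1.8-fold higher number from compound 1 to compound 4 (0.24 log units; within the scatter), so the compounds shown leave it open whether the attachment point of the pyrazole matters once the chain is isopropyl. The 1-isopropyl-1H-pyrazol-3-yl group would test this directly, while a tert-butyl group, a longer chain or a chain ending in an amine would show how far the flat outcome extends.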